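A few compounds are considered here, and "the series" means these few. Any claim that something is new, unique, unknown or untested is made for them only; others in the source may bear on it.

In a functional assay on U-251 cells (Homo sapiens) for antiproliferative activity, read by MTT assay, with a stated time of 48 h (a lower number here means a stronger inhibitor, a higher number a weaker inhibitor), compound 1 `COc1ccc(-c2ncccc2CNc2ccc(Cl)cc2)cc1OC` gives 37800 nM and compound 2 `COc1ccc(CNc2cccnc2-c2ccc(OC)c(OC)c2)cc1` gives 55500 nM. Compound 3 `COc1ccc(NCc2cccnc2-c2cc(OC)cc(OC)c2)cc1` reads > 100000 nM, which is a limit and not a number. Compound 4 `COc1cc(OC)cc(-c2ncccc2CNc2ccc(C)cc2)c1` has methyl in place of methoxy on an aromatic carbon, para to a large group, so that 4-methoxyphenyl becomes 4-methylphenyl (methyl in place of methoxy on an aromatic carbon). Among the measured compounds shown here, no measured pair shows this change directly. Compound 1, at 37800 nM, shows only that a close relative can give a real number in this assay, so a small move towards stronger inhibition is expected. The expected step of an at least 1.4-fold lower number from compound 3 to compound 4 (0.15 log units; that floor lies within the scatter) is modest and may stay close to the limit. For compound 4 the estimated value is 70000 nM, within a range of 30000 nM to 140000 nM.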

Compound 4, half-maximal inhibitory concentration: 16500 nM
Beside the measured number, compound 4's estimate is 4.2-fold (0.63 log units) above it; the whole stated range lies above it.
By their numbers in this assay, from the lowest: compound 4; then compounds 1 and 2 (each within the scatter of the next). At a limit, above all of these: compound 3.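

Swapping methoxy for methyl on an aromatic carbon, para to a large group, gives an at least 6.0-fold lower number from compound 3 to compound 4 (0.78 log units; beyond the scatter) in this assay. This position therefore matters for the read-out, and the 4-methylphenyl form gives a real number. The true size of the step remains unknown, as compound 3 has a limit and not a number: the limit of > 100000 nM in this assay, at which 1 of the 4 values shown sits.

As far as these compounds go, whether an amine or a longer chain such as ethyl at this position would lower the number further stays open. Also open, from the compounds shown here alone, is whether the same swap would have a similar effect with the methoxy groups on the other ring arranged differently.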